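Replacing the 4-aminophenyl group of compound 3

The source may hold more compounds than are shown below. What is called first, only, known or untested is meant among the compounds shown, and "the series" means these compounds.

Values in a functional assay on MIA PaCa-2 cells (Homo sapiens) for cytotoxicity, read by MTT assay, with a stated time of 4 h (a lower number here means a stronger inhibitor, a higher number a weaker inhibitor), so far:
- compound 1 `COC1=CC(=O)c2c(c(COc3ccncc3)c(C)n2C)C1=O` gives 2010 nM
- compound 2 `COC1=CC(=O)c2c(c(C(C)Oc3ccc([N+](=O)[O-])cc3)c(C)n2C)C1=O` gives 1830 nM
- compound 3 `COC1=CC(=O)c2c(COc3ccc(N)cc3)c(C)n(C)c2C1=O` gives 504 nM

Compound 3 has the lowest number of the three, and compound 1 and compound 2 both lie above it beyond the scatter. The next compound is compound 4 `COC1=CC(=O)c2c(COc3cccnc3)c(C)n(C)c2C1=O` with pyridin-3-yl in place of 4-aminophenyl on an oxygen on a saturated carbon. Going by the values given here, no measured pair isolates this change. A weaker result is expected because compound 1 at 2010 nM also carries a six-membered aromatic ring with 1 hetero atom on such an oxygen, although its core is not identical. The expected step in this assay is a 3.0-fold higher number from compound 3 to compound 4 (0.47 log units; beyond the scatter) and would lie beyond the scatter. For compound 4 the estimated value is 1500 nM with an expected range of 550 nM to 4000 nM.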

Compound 4, half-maximal inhibitory concentration: 2480 nM
Estimate against measurement, compound 4: 1.7-fold (0.22 log units) below; the measured number falls inside the stated range.
By their numbers in this assay, from the lowest: compound 3; then compounds 2, 1 and 4 (each within the scatter of the next).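

In this assay, going by these compounds alone, pyridin-3-yl in place of 4-aminophenyl gives a 4.9-fold higher number from compound 3 to compound 4 (0.69 log units; beyond the scatter), the first step that can be read on a single change. This shows that the group on this oxygen affects the number on the shared core, although the change replaces the ring and removes a hydrogen-bond donor together. No measurement here explains the step.

As far as these compounds go, whether the lower number of compound 3 depends on the amine or on the all-carbon ring remains open. Plain phenyl or 4-hydroxyphenyl on the same oxygen would separate the two.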